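The source may report more compounds than this note shows. Statements on the series, on what has been measured and on what is new or still open speak of the compounds shown alone.

Measured compounds:
Compound 1 `O=C(Nc1ccc(Cl)c(-c2nnc3c(Cl)cccn23)c1)c1cccc(Cl)c1` gives 43100 nM.
Compound 2 `CS(=O)(=O)c1ccc(C(=O)Nc2ccc(Cl)c(-c3nnc4c(Cl)cccn34)c2)cc1` gives > 100000 nM, which is a limit of the assay, not a number.
Compound 3 `O=C(Nc1ccc(Cl)c(-c2nnc3c(Cl)cccn23)c1)c1cccnc1Cl` gives > 100000 nM, again a limit.

In a functional assay on U-251 cells (Homo sapiens) for antiproliferative activity, read by MTT assay, with a stated time of 72 h (a lower number here means a stronger inhibitor, a higher number a weaker inhibitor), compound 2 therefore stands at the limit, where two of the three values sit (the limit of > 100000 nM in this assay, at which 2 of the 3 values shown sit). Compound 4 `O=C(Nc1ccc(Cl)c(-c2nnc3c(Cl)cccn23)c1)c1ccccc1Cl` differs from it by 2-chlorophenyl in place of 4-(methylsulfonyl)phenyl on a carbonyl carbon. The step that bears on this is the reverse of an at least 2.3-fold higher number from compound 1 to compound 2 (0.36 log units; beyond the scatter), where a chlorophenyl left and the methylsulfonylphenyl arrived; the step that the two limits leave unreadable from compound 2 to compound 3 gives no readable size. Returning a chlorophenyl group is thus expected to bring the number back down from the limit, by roughly an at least 1.8-fold lower number from compound 2 to compound 4 (0.25 log units; that floor lies within the scatter). Compound 4 is estimated at 55000 nM, between 20000 nM and 150000 nM.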

Compound 4, half-maximal inhibitory concentration: > 100000 nM
Compound 4 was reported as a limit (the forecaster's own chance of this, stated with the estimate: 40%); middle value at least 1.8-fold (0.25 log units) away from the limit.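

In this assay, 2-chlorophenyl in place of 3-chlorophenyl on the carbonyl carbon gives an at least 2.3-fold higher number from compound 1 to compound 4 (0.36 log units; beyond the scatter), so a change in where the chlorine sits on that phenyl is enough to reach the limit, with no change of atoms. Compound 4 gives a limit and not a number, so its steps to compound 2 and compound 3 cannot be read. Compound 1 remains the only compound with a number: the limit of > 100000 nM in this assay, at which 3 of the 4 values shown sit.

The compounds shown leave open whether an unsubstituted phenyl, or a phenyl carrying a methoxy group or an amine in place of the chlorine, would give a number rather than a limit.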